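A few compounds are considered here, and "the series" means these few. Any claim that something is new, unique, unknown or untested is made for them only; others in the source may bear on it.

Of the compounds shown here, three sharing one core have been tested for how strongly they act on a cervical cancer cell line, and a fourth awaits testing. Compound 1 `CCS[C@@H]1[C@H](SCC)[C@@H](Cn2cc(-c3ccc(C)cc3)nn2)O[C@H]1n1ccc(=O)[nH]c1=O` carries a 4-methylphenyl group; in a functional assay on HeLa cells (Homo sapiens) for cytotoxicity, read by MTT assay, with a stated time of 72 h (on this read-out higher numbers stand for an effect only at larger amounts of compound and lower numbers for an effect already at smaller amounts), compound 1 gives 46700 nM. Compound 2 `CCOC(=O)c1cn(C[C@H]2O[C@@H](n3ccc(=O)[nH]c3=O)[C@H](SCC)[C@@H]2SCC)nn1` differs from compound 1 by ethoxycarbonyl in place of 4-methylphenyl on an aromatic carbon. In this assay compound 2 reaches only a limit of the assay, >= 100000 nM. The step is an at least 2.1-fold higher number from compound 1 to compound 2 (0.33 log units; beyond the scatter), open-ended because compound 2 sits at the limit of >= 100000 nM in this assay, at which 1 of the 3 values shown sits. Compound 3 `CCS[C@@H]1[C@H](SCC)[C@@H](Cn2cc(-c3ccc(C)cc3)nn2)O[C@H]1n1cc(C)c(=O)[nH]c1=O` gives 77500 nM in this assay, a change of a 1.7-fold higher number from compound 1 to compound 3 (0.22 log units; within the scatter). Compound 4 `CCOC(=O)c1cn(C[C@H]2O[C@@H](n3cc(C)c(=O)[nH]c3=O)[C@H](SCC)[C@@H]2SCC)nn1` has not been measured; it differs from compound 3 by ethoxycarbonyl in place of 4-methylphenyl on an aromatic carbon, the same change that leads from compound 1 to compound 2, and the cores of compound 3 and compound 4 differ from those of compound 1 and compound 2 by methyl in place of hydrogen on an aromatic carbon. Since that change gave an at least 2.1-fold higher number from compound 1 to compound 2 (0.33 log units; beyond the scatter) the first time, compound 4 is expected to move by a similar step, a 2.2-fold higher number from compound 3 to compound 4 (0.34 log units; beyond the scatter), most likely ending at the limit. Compound 4 is therefore estimated at about 170000 nM, between 90000 nM and 400000 nM.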

Compound 4, half-maximal effective concentration: >= 100000 nM
Compound 4: no number, only a limit; the forecaster's own chance of this, stated with the estimate: 75%; the middle value is on the limit's open side.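

In this assay compound 4 reaches only a limit of the assay, >= 100000 nM. Putting ethoxycarbonyl in place of 4-methylphenyl on the core that carries the extra methyl gives an at least 1.2-fold higher number from compound 3 to compound 4 (0.11 log units; that floor lies within the scatter), so the result fits what the same change did on the first core but does not show that the effect carries over at the same size: the same change on two cores in this assay, an at least 2.1-fold higher number (0.33 log units; beyond the scatter) from compound 1 to compound 2 and an at least 1.2-fold higher number (0.11 log units; that floor lies within the scatter) from compound 3 to compound 4; the limit leaves it open whether they differ. The step from compound 2 to compound 4 cannot be read, so these compounds do not show what the methyl on the core does when ethoxycarbonyl is present: the limit of >= 100000 nM in this assay, at which 2 of the 4 values shown sit.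

Going by these compounds, how far compound 2 and compound 4 really lie beyond their limits remains open. The compounds shown also leave open whether a different group at this place on the five-membered aromatic ring, such as an amine, a carboxylic acid or a longer chain, would give a lower number than 4-methylphenyl does.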